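Swapping One Halogen on a Weak Growth Inhibitor

The compounds below may be only part of what the source reports. "The series", "measured", "known", "first", "only" and "open" are said of these compounds alone.

Measured compounds:
- compound 1, `O=C(/C(=C\c1ccc(Cl)cc1)S(=O)(=O)c1ccc(Br)cc1)c1ccc(Br)cc1`: 50000 nM
- compound 2, `O=C(O)c1ccc(C(=O)/C(=C\c2ccc(F)c([N+](=O)[O-])c2)SCc2ccc(Cl)cc2Cl)cc1`: 1000 nM

In a functional assay on DU-145 cells (Homo sapiens) for inhibition, read by trypan blue exclusion, with a stated time of 96 h (on this read-out higher numbers stand for weaker inhibition of growth and lower numbers for stronger inhibition of growth), compound 1 gives 50000 nM, the highest of the two numbers and so the weakest growth inhibition seen here. Compound 2 gives 1000 nM, a much lower number, and the gap between the two is beyond the usual scatter. The two compounds differ in many places at once, so their gap says nothing about any single change.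

Compound 3, `O=C(/C(=C\c1ccc(I)cc1)S(=O)(=O)c1ccc(Br)cc1)c1ccc(Br)cc1`, differs from compound 1 in one place only: iodo in place of chloro on an aromatic carbon. For the measured compounds named here, no measured pair shows this exchange, so its effect in this assay is unknown. With nothing to suggest otherwise, the expected step of a 1.3-fold lower number from compound 1 to compound 3 (0.10 log units; within the scatter) is none beyond the scatter, with a small lean toward a lower number. Compound 3 is therefore estimated at 40000 nM, expected to fall between 15000 nM and 100000 nM.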

Compound 3, concentration for 50% growth inhibition: 1000 nM
Compound 3: middle estimate off by 40-fold (1.60 log units), on the high side; the measured number lies below the stated range.
By their numbers in this assay, from the lowest: compounds 2 and 3 (each within the scatter of the next); then compound 1.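

In this assay, the halogen on the 4-chlorophenyl group proves to be far from a minor detail: iodo in place of chloro gives a 50-fold lower number from compound 1 to compound 3 (1.70 log units; beyond the scatter) with the rest of the structure unchanged. For the compounds shown here, the earlier compounds differed in many places at once, so this pair is the first to tie a large change in growth inhibition to one position, on an aromatic carbon of the ring. Nothing among the data shown explains why this single exchange matters so much.

Going by these compounds, whether this strong growth inhibition is particular to iodo remains open, since only chloro and iodo appear at this position, and an amine or a methoxy group there could read either way. On these data alone, it also remains open whether the same exchange would have a similar effect on a different core.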